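The source may hold more compounds than are shown below. What is called first, only, known or untested is meant among the compounds shown, and "the series" means these compounds.

Measured so far: compound 2 `COc1cccc(NC(=O)c2ccc(OC)c(Nc3nccc(-c4cccnc4)n3)c2)c1` gives 93100 nM in a functional assay on K562 cells (Homo sapiens) for antiproliferative activity, read by MTT assay, with a stated time of 48 h; a higher number here means a weaker inhibitor, a lower number a stronger inhibitor. Compound 1 `COc1ccc(C(=O)Nc2nccs2)cc1Nc1nccc(-c2cccnc2)n1` shares the same core, but in this assay compound 1 gives "not determined" (no result reported), so no number was reported for it in this assay.

Compound 2 thus carries the only number shown, and it is a weak one. Compound 3 `COc1ccc(C(=O)Nc2cc(Br)cc(C(F)(F)F)c2)cc1Nc1nccc(-c2cccnc2)n1` differs by 3-bromo-5-(trifluoromethyl)phenyl in place of 3-methoxyphenyl on an amide-type nitrogen. Among the compounds with values here, no step between measured compounds with this change is available, so the direction rests on expectation alone. A moderate gain in potency is expected, with the step from compound 2 to compound 3 estimated at a 4.7-fold lower number from compound 2 to compound 3 (0.67 log units; beyond the scatter). Compound 3 is therefore expected to reach 20000 nM, within a range from 3000 nM to 100000 nM.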

Compound 3, half-maximal inhibitory concentration: 215000 nM
The estimate for compound 3 lay 11-fold (1.03 log units) below the measured number, outside the stated range (above it).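

In this assay, placing 3-bromo-5-(trifluoromethyl)phenyl in place of 3-methoxyphenyl on the amide-type nitrogen gives a 2.3-fold higher number from compound 2 to compound 3 (0.36 log units; beyond the scatter). This shows that the group at this position can shift the number, and that this change makes the inhibitor weaker rather than stronger. Nothing available explains the direction of this step.

From the compounds shown here alone, it remains open whether bromine alone or trifluoromethyl alone on the ring would produce the same shift. Also open, going by these compounds, is how an unsubstituted phenyl or a chain ending in an amine would compare at this nitrogen.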